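The source may report more compounds than this note shows. Statements on the series, on what has been measured and on what is new or still open speak of the compounds shown alone.

Series notes. Within the data shown here, compound 1 `CCC(=O)N1N=C(c2ccccc2)CC1c1ccc(C)cc1` and compound 2 `CCC(=O)N1N=C(c2ccc(C)cc2)CC1c1ccc(C)cc1` are the two measured members. In an assay on isolated protein for inhibition of Amine oxidase [flavin-containing] B (Bos taurus) (on this read-out lower numbers stand for stronger inhibition and higher numbers for weaker inhibition), compound 1 gives 100000 nM. Compound 2 gives 100000 nM in this assay. The one measured step, methyl in place of hydrogen on an aromatic carbon, reads no change at the digits printed from compound 1 to compound 2 (within the scatter), so compound 2 stands level with compound 1 at the digits shown, with no change beyond the scatter.

Compound 3 `CCC(=O)N1N=C(c2ccc(C)cc2)CC1c1ccc(OC)cc1` is the next member, not yet measured. It differs from compound 2 by methoxy in place of methyl on an aromatic carbon. Among the measured compounds shown here, no measured step involves a methoxy group, so the only comparison at hand is the step from compound 1 to compound 2, which was flat. Both measured compounds sit at the same weak level, and a change of one aromatic substituent for another of similar size gives no basis to expect a departure from it. For compound 3 the expected step is therefore no change at the digits printed from compound 2 to compound 3 (within the scatter), that is, none beyond the scatter. Compound 3 is estimated at 100000 nM in this assay, within a range of 30000 nM to 100000 nM.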

Compound 3, half-maximal inhibitory concentration: 100000 nM
Compound 3: middle estimate and measured number agree at the digits printed; low and high end bracket the measured number.
By their numbers in this assay, from the lowest: compounds 1, 2 and 3 (each within the scatter of the next).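

In this assay, among these compounds, the change from 4-methylphenyl to 4-methoxyphenyl reads no change at the digits printed from compound 2 to compound 3 (within the scatter) and is the first reading on this aromatic ring, since the earlier step altered the other one. With compound 3 at 100000 nM in this assay, the methoxy group, with its oxygen and one hydrogen-bond acceptor by the count, leaves the printed value where the methyl group had it, so substitution on either aromatic ring has so far given no difference across these three compounds. No supporting measurement bears on this flat result.

The compounds shown leave open whether a group of another kind on this aromatic carbon, such as an amine, a carboxylic acid or a longer alkoxy chain, would give a value apart from the one shared so far. With all three compounds at the same printed value, they also leave open how far this read-out can separate substituents at this position, and what changes elsewhere on the shared core would do.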